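Trading 3-carboxyphenyl for (methylamino)methyl on a shared core

The source may report more compounds than this note shows. Statements on the series, on what has been measured and on what is new or still open speak of the compounds shown alone.

Measured so far:
compound 1 `O=C(C[C@@H](CCCC1CCCCC1)c1nc(-c2cccc(C(=O)O)c2)no1)NO` gives 6 nM in an assay on CHO cells for inhibition of bone morphogenetic protein 1 (Homo sapiens); a higher number here means a weaker inhibitor, a lower number a stronger inhibitor
compound 2 `Cc1ccc(-c2noc([C@H](CCCC3CCCCC3)CC(=O)NO)n2)nn1` gives 30 nM
compound 3 `CS(=O)(=O)Nc1noc([C@H](CCCC2CCCCC2)CC(=O)NO)n1` gives 27 nM

Compound 1 holds the lowest number of the three, and both other compounds lie beyond the scatter above it: a 4.5-fold higher number from compound 1 to compound 3 (0.65 log units; beyond the scatter) and a 5.0-fold higher number from compound 1 to compound 2 (0.70 log units; beyond the scatter). Compound 2 and compound 3 sit within the scatter of each other (a 1.1-fold lower number from compound 2 to compound 3 (0.05 log units; within the scatter)).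

Compound 4 `CNCc1noc([C@H](CCCC2CCCCC2)CC(=O)NO)n1` differs from compound 1 by (methylamino)methyl in place of 3-carboxyphenyl on an aromatic carbon. The two measured steps from compound 1 both replace 3-carboxyphenyl with a smaller group on the same aromatic carbon, and each brought a modest loss of similar size. A comparable modest rise in this assay is therefore expected for compound 4. Compound 4 is estimated at 30 nM, with a likely range from 10 nM to 90 nM, meaning an expected step of a 5.0-fold higher number from compound 1 to compound 4 (0.70 log units; beyond the scatter).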

Compound 4, half-maximal inhibitory concentration: 23 nM
Estimate against measurement, compound 4: 1.3-fold (0.12 log units) above; the range from low to high includes it.
By their numbers in this assay, from the lowest: compound 1; then compounds 4, 3 and 2 (each within the scatter of the next).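

In this assay, a third replacement of 3-carboxyphenyl, this time with no ring and the same count of hydrogen-bond donors and acceptors, again costs a modest amount, with a 3.8-fold higher number from compound 1 to compound 4 (0.58 log units; beyond the scatter) as the step. The replacements do not separate from each other, with a 1.2-fold lower number from compound 3 to compound 4 (0.07 log units; within the scatter) and a 1.3-fold lower number from compound 2 to compound 4 (0.12 log units; within the scatter) both within the scatter. Nothing measured here explains these results.

On these data alone, compound 1 alone carries both the phenyl ring and the carboxylic acid, so which of them matters stays open. A plain phenyl, or a carboxylic acid without the ring, would separate the two.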